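The source may hold more compounds than are shown below. What is called first, only, known or untested is meant among the compounds shown, and "the series" means these compounds.

The measured compounds:
Compound 1 `COc1cc(C(=O)c2sc3ccccc3c2-c2ccc(C)cc2)cc(OC)c1OC`: 7800 nM
Compound 2 `COc1ccc(-c2c(C(=O)c3cc(OC)c(OC)c(OC)c3)sc3ccccc23)c(OC)c1`: 5800 nM
Compound 3 `COc1ccc(-c2c(C(=O)c3cc(OC)c(OC)c(OC)c3)sc3ccccc23)cc1C`: > 10000 nM, a limit of the assay

In a functional assay on A549 cells (Homo sapiens) for antiproliferative activity, read by MTT assay, with a stated time of 72 h (on this read-out lower numbers stand for stronger inhibition and higher numbers for weaker inhibition), compound 1 gives 7800 nM, the higher of the two numbers shown. Compound 2 gives 5800 nM, and the step is a 1.3-fold lower number from compound 1 to compound 2 (0.13 log units; within the scatter). For compound 3 the assay reports only a limit, > 10000 nM. The steps involving it are an at least 1.2-fold higher number from compound 1 to compound 3 (0.10 log units; that floor lies within the scatter) and an at least 1.7-fold higher number from compound 2 to compound 3 (0.23 log units; that floor lies within the scatter), each resting on that floor. All three measured steps exchange one substituted phenyl group for another on the same aromatic carbon, and none of them moves beyond the scatter.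

Compound 4 `COc1cc(C(=O)c2sc3ccccc3c2Nc2ccc(C)cc2)cc(OC)c1OC` differs from compound 1 in one place: (4-methylphenyl)amino in place of 4-methylphenyl on an aromatic carbon. For the measured compounds named here, no measured step inserts a linking nitrogen between the core and the phenyl group, so none bears directly on this change. The expectation therefore rests on compound 1 itself and carries a wide range. Compound 4 is estimated at 6500 nM, between 1500 nM and 25000 nM. The expected step is a 1.2-fold lower number from compound 1 to compound 4 (0.08 log units; within the scatter).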

Compound 4, half-maximal inhibitory concentration: 2600 nM
Compound 4: the middle estimate sits 2.5-fold (0.40 log units) above what was measured, within the range that was stated.
By their numbers in this assay, from the lowest: compound 4; then compounds 2 and 1 (each within the scatter of the next). At a limit, above all of these: compound 3.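

With the (4-methylphenyl)amino group in place of 4-methylphenyl on this aromatic carbon, this assay shows a change beyond the scatter, a 3.0-fold lower number from compound 1 to compound 4 (0.48 log units; beyond the scatter), whereas exchanges among directly attached substituted phenyl groups had not moved beyond it. Compound 4 also separates from the 2,4-dimethoxyphenyl compound, with a 2.2-fold lower number from compound 2 to compound 4 (0.35 log units; beyond the scatter), and from the 4-methoxy-3-methylphenyl compound, with an at least 3.8-fold lower number from compound 3 to compound 4 (0.58 log units; beyond the scatter). Compound 3 stands at a limit of the assay, so that last step is only a floor: the limit of > 10000 nM in this assay, at which 1 of the 4 values shown sits.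

The compounds shown leave open whether an ether oxygen or a methylene link at this carbon would do what the amino link does. They also leave open whether the amino hydrogen matters, which an N-methylamino link would test, and whether the 2,4-dimethoxyphenyl group would follow the same course on an amino link.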